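The source may report more compounds than this note shows. Statements on the series, on what has been measured and on what is new or still open speak of the compounds shown alone.

Measured compounds:
Compound 1, `Nc1cc(N)c2nc(-c3ccccc3)c(Oc3ccc(Cl)c(Cl)c3)nc2c1`: in a functional assay on OVCAR-4 cells (Homo sapiens) for inhibition, read by sulforhodamine B assay, with a stated time of 48 h (a lower number here means a stronger inhibitor of growth, a higher number a weaker inhibitor of growth), compound 1 gives < 100000 nM, a limit of the assay and not a number.
Compound 2, `Nc1cc(N)c2nc(-c3ccccc3)c(NCc3ccc(Cl)c(Cl)c3)nc2c1`: compound 2 gives < 100000 nM, likewise a limit.
Compound 3, `Nc1cc(N)c2nc(-c3ccccc3)c(NCc3ccc(F)cc3)nc2c1`: compound 3 gives 8130 nM.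

For the measured compounds named here, compound 3 thus holds the only number in the set; the two other values sit at the limit of < 100000 nM in this assay, at which 2 of the 3 values shown sit. Compound 4, `COc1ccc(Sc2nc3cc(N)cc(N)c3nc2-c2ccccc2)cc1`, carries (4-methoxyphenyl)sulfanyl in place of (4-fluorobenzyl)amino on an aromatic carbon. The measured steps at this position, a step that the limit leaves unreadable from compound 1 to compound 3 and a step that the limit leaves unreadable from compound 2 to compound 3, are both unreadable in size, so they give no calibration for the present change, which is itself untested in the series. Compound 4 is therefore expected near compound 3, at 12000 nM, with a wide range from 2500 nM to 60000 nM. This amounts to an expected step of a 1.5-fold higher number from compound 3 to compound 4 (0.17 log units; within the scatter).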

Compound 4, concentration for total growth inhibition: < 100000 nM
Compound 4: no number, only a limit; the forecaster's own chance of this, stated with the estimate: 25%; the middle value lies beyond the limit too.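

In this assay compound 4 gives < 100000 nM, a limit and not a number, so neither its step from compound 3 nor its step from compound 1 can be read: the limit of < 100000 nM in this assay, at which 3 of the 4 values shown sit.

On these data alone, how far (4-methoxyphenyl)sulfanyl in place of (4-fluorobenzyl)amino moves the number on the shared core stays open.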